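Swapping a Hydroxy for Diethylamino on the Side Chain

This account rests on a few compounds, and the source may have more. Where it says the series, first, only, none or still open, it means among the compounds named here.

Among the compounds with values here, compound 3 `O=C1C2=C(C(=O)c3ccccc31)C1(CS2)NC(=O)N(CCCO)C1=O` gives 40 nM in a functional assay on MCF7 cells (Homo sapiens) for inhibition (on this read-out higher numbers stand for weaker inhibition and lower numbers for stronger inhibition), the lowest of the three numbers measured so far. Compound 1 `CCCCN1C(=O)NC2(CSC3=C2C(=O)c2ccccc2C3=O)C1=O` gives 178 nM and compound 2 `CCC(C)N1C(=O)NC2(CSC3=C2C(=O)c2ccccc2C3=O)C1=O` gives 178 nM in this assay, and no change at the digits printed from compound 1 to compound 2 (within the scatter). The steps of a 4.5-fold lower number from compound 1 to compound 3 (0.65 log units; beyond the scatter) and a 4.5-fold lower number from compound 2 to compound 3 (0.65 log units; beyond the scatter) show that the chain bearing a hydroxy gave the lower number. Compound 4 `CCN(CC)CCCN1C(=O)NC2(CSC3=C2C(=O)c2ccccc2C3=O)C1=O` carries diethylamino in place of hydroxy on a saturated chain carbon, three bonds along the chain from an amide-type nitrogen in a ring. Within the data shown here, no measured step pairs a hydroxy with an amine, so the earlier steps bear only indirectly: chains without the hydroxy gave higher numbers in this assay. The expected step is therefore a 2.3-fold higher number from compound 3 to compound 4 (0.35 log units; beyond the scatter), a modest rise, with a value within the scatter also possible. Compound 4 is estimated at 90 nM, with a likely range from 30 nM to 300 nM.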

Compound 4, half-maximal inhibitory concentration: 26 nM
The estimate for compound 4 lay 3.5-fold (0.54 log units) above the measured number; measured number outside the range, below it.
By their numbers in this assay, from the lowest: compounds 4 and 3 (each within the scatter of the next); then compounds 1 and 2 (each within the scatter of the next).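

The step of a 1.5-fold lower number from compound 3 to compound 4 (0.19 log units; within the scatter) shows that a hydroxy is not required at this chain position in this assay: diethylamino, with no hydrogen-bond donor, gives a number within the scatter of it. The steps of a 6.8-fold lower number from compound 2 to compound 4 (0.84 log units; beyond the scatter) and a 6.8-fold lower number from compound 1 to compound 4 (0.84 log units; beyond the scatter) set compound 4 apart from the butyl and sec-butyl chains, as compound 3 already was. Nothing here shows what the two end groups share that could account for this. Going by these compounds, a morpholine or a carboxylic acid on the same chain remains open, as does 2-(diethylamino)ethyl in place of 3-(diethylamino)propyl.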